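The compounds below may be only part of what the source reports. "The series", "measured", "known", "first", "only" and "open" are said of these compounds alone.

Compound 1 `O=C(c1ccncc1)N1N=C(c2cc3ccccc3o2)CC1c1ccccc1O`: > 195000 nM
Compound 2 `COc1ccc(C2CC(c3cc4ccccc4o3)=NN2C(=O)c2ccncc2)c(O)c1`: > 190000 nM

In an ADME assay on Vero cells (Chlorocebus sabaeus) for cytotoxicity, read by MTT assay, with a stated time of 72 h (a lower number here means a stronger inhibitor, a higher number a weaker inhibitor), compound 2 stands at > 190000 nM, which is a limit of the assay and not a number. Compound 1 also gives only a limit, > 195000 nM, so neither compound has an exact reading. Going by the values given here, the one measured step, methoxy in place of hydrogen on an aromatic carbon, is a step that the two limits leave unreadable from compound 1 to compound 2, and it offers no size to build on.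

Compound 3 `O=C(c1ccncc1)N1N=C(c2cc3ccccc3o2)CC1c1ccccc1[N+](=O)[O-]` carries 2-nitrophenyl in place of the 2-hydroxy-4-methoxyphenyl of compound 2 on a saturated ring carbon, while the rest of the structure stays the same: 2-nitrophenyl in place of 2-hydroxy-4-methoxyphenyl on a saturated ring carbon. Among the compounds with values here, neither measured compound carries 2-nitrophenyl, so no measured step speaks directly to this change. With only limits to go on, no step beyond the scatter is expected in this assay, in either direction, although a reading toward lower numbers remains possible. The expected step is an at least 1.0-fold lower number from compound 2 to compound 3 (0.02 log units; that floor lies within the scatter). Compound 3 may well return only a limit too. For compound 3 the estimated value is 180000 nM, with an expected range of 60000 nM to 200000 nM.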

Compound 3, half-maximal inhibitory concentration: > 245000 nM
Compound 3 ended at the assay's limit (the forecaster's own chance of this, stated with the estimate: 65%); at least 1.3-fold (0.13 log units) between middle value and limit.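

In this assay compound 3 gives > 245000 nM, which is a limit of the assay and not a number. Going by these compounds alone, compound 1 and compound 2 also give only limits, so no step linking compound 3 to either can be read. The compounds shown leave open where an exact reading for any of the three would fall, and whether 2-nitrophenyl makes any difference.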